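The source may report more compounds than this note shows. Statements on the series, on what has been measured and on what is new or still open speak of the compounds shown alone.

Measured compounds:
- compound 1 `O=C(O)c1cccc([C@H]2C[C@@H](c3ccc(OCc4c(-c5c(Cl)cccc5Cl)noc4C4CC4)cc3Cl)C2)c1`: 92 nM
- compound 2 `O=C(O)c1cccc(N2CC(O)(c3ccc(OCc4c(-c5c(Cl)cccc5Cl)noc4C4CC4)cc3Cl)C2)c1`: 86 nM
- compound 3 `O=C(O)c1cccc(C2CC2c2ccc(OCc3c(-c4c(Cl)cccc4Cl)noc3C3CC3)cc2Cl)c1`: 34 nM

Among the measured compounds shown here, the three measured members share one core and differ in the linker that joins the carboxyphenyl acid to the chlorinated aryl ether. In an assay on HEK293 cells for agonist activity at Bile acid receptor (Homo sapiens) (a lower number here means that less compound is needed, a higher number that more compound is needed for the effect), compound 1 gives 92 nM and compound 2 gives 86 nM; these two values lie within the scatter of each other and are not ordered. For the measured compounds named here, compound 3, with the cyclopropane linker, gives 34 nM in this assay, the lowest of the three numbers, and its distance to each of the other two is beyond the scatter, so compound 3 is the most potent compound measured so far.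

Compound 4 `O=C(O)c1cncc(C2CC2c2ccc(OCc3c(-c4c(Cl)cccc4Cl)noc3C3CC3)cc2Cl)c1` keeps the cyclopropane linker of compound 3 and changes only the acid-bearing ring: 5-carboxypyridin-3-yl in place of 3-carboxyphenyl on a saturated ring carbon. Going by the values given here, no measured pair in the set shows the effect of this change, so the expectation rests on compound 3 alone. An aza-replacement on the acid ring is taken as a small adjustment; the step from compound 3 to compound 4 is expected to be a 1.3-fold higher number from compound 3 to compound 4 (0.12 log units; within the scatter), that is, no change beyond the scatter, with a slight lean toward a higher number. Compound 4 is therefore estimated at 45 nM in this assay, within a range of 15 nM to 150 nM.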

Compound 4, half-maximal effective concentration: 14 nM
Compound 4: the middle estimate sits 3.2-fold (0.51 log units) above what was measured; measured number below the stated range.
By their numbers in this assay, from the lowest: compound 4; then compound 3; then compounds 2 and 1 (each within the scatter of the next).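

In this assay, 5-carboxypyridin-3-yl in place of 3-carboxyphenyl on a saturated ring carbon of the three-membered ring gives a 2.4-fold lower number from compound 3 to compound 4 (0.39 log units; beyond the scatter), a modest step but one beyond the scatter. Among the compounds shown here, the earlier compounds differed only in the linker and all carried 3-carboxyphenyl, so this is the first reading of the acid-bearing ring as a place where the number can move, and it shows that a ring nitrogen there is tolerated with the cyclopropane linker and goes with less compound being needed. Nothing available explains the direction or size of this step, which stands as an observation from a single pair.

The compounds shown leave open whether the same exchange would give a step of similar size and direction on the linkers of compound 1 and compound 2, since a single pair cannot show whether the effect carries over to another linker. They also leave open how the 5-carboxypyridin-3-yl ring would respond to a further substituent such as a fluorine or a methyl group, or to a tetrazole in place of the carboxylic acid.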